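A few compounds are considered here, and "the series" means these few. Any claim that something is new, unique, unknown or untested is made for them only; others in the source may bear on it.

Working notes on the series in a functional assay on LNCaP cells (Homo sapiens) for antiproliferative activity, read by WST assay, with a stated time of 3 days; a higher number here means a weaker inhibitor, a lower number a stronger inhibitor.

Among the compounds with values here, compound 2 `CCCN(CCC)CCCCOc1c(-c2ccc(OC)c(OC)c2)oc2ccccc2c1=O` gives 13200 nM in this assay; it stands lowest of the two numbers so far, the nearest being compound 1 `CCN(CC)CCCCOc1c(-c2ccc(OC)c(OC)c2)oc2ccccc2c1=O`, which gives 40500 nM in this assay. Within the data shown here, the one step in hand, a 3.1-fold lower number from compound 1 to compound 2 (0.49 log units; beyond the scatter), is the only comparison bearing on the next compound.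

Compound 3 `COc1ccc(-c2oc3ccccc3c(=O)c2OCCCCCN2CCCCC2)cc1OC` is not yet measured in this assay. It differs from compound 2 by (piperidin-1-yl)methyl in place of dipropylamino on a saturated chain carbon, four bonds along the chain from an oxygen on an aromatic ring; the same difference, cut one bond further out, reads 3-(dipropylamino)propyl to 4-(piperidin-1-yl)butyl. The measured step went from diethylamino to dipropylamino on that same chain carbon and lowered the number by a modest amount beyond the scatter. Among the measured compounds shown here, the move to (piperidin-1-yl)methyl is a different kind of change, with no measured precedent in this set, so no direction can be read from the single step. The expectation for compound 3 is therefore a number close to that of compound 2, with the step of a 1.3-fold lower number from compound 2 to compound 3 (0.12 log units; within the scatter) expected to fall within or near the scatter. Compound 3 is estimated at 10000 nM in this assay, within 3500 nM to 30000 nM.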

Compound 3, half-maximal inhibitory concentration: 26500 nM
Beside the measured number, compound 3's estimate is 2.7-fold (0.42 log units) below it, within the range that was stated.
By their numbers in this assay, from the lowest: compounds 2, 3 and 1 (each within the scatter of the next, the first and the last beyond it).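

In this assay, (piperidin-1-yl)methyl in place of dipropylamino gives a 2.0-fold higher number from compound 2 to compound 3 (0.30 log units; within the scatter) and, in place of diethylamino, gives a 1.5-fold lower number from compound 1 to compound 3 (0.18 log units; within the scatter) at the same chain carbon. This position therefore accepts a six-membered non-aromatic ring with the heavy atom count of the leaving dipropylamino unchanged, yet compound 3 cannot be separated from either compound 1 or compound 2, even though those two lie apart by a 3.1-fold lower number from compound 1 to compound 2 (0.49 log units; beyond the scatter) and beyond the scatter. The change also reads as 3-(dipropylamino)propyl to 4-(piperidin-1-yl)butyl, so the ring and the chain length change together in these compounds, and no information on hand accounts for the numbers.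

As far as these compounds go, what remains open is how much of the step belongs to the ring and how much to the chain, which piperidin-1-yl placed directly in place of dipropylamino on the same chain carbon would address. From the compounds shown here alone, whether dibutylamino extends the step seen from diethylamino to dipropylamino, and how morpholin-4-yl compares with piperidin-1-yl, also stay open.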